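A few compounds are considered here, and "the series" means these few. Any claim that something is new, unique, unknown or untested is made for them only; others in the source may bear on it.

Within the data shown here, compound 1 `Cc1cc2c(cc1C(=O)N=C(N)N)S(=O)(=O)CC2(C)O` and compound 2 `Cc1cc2c(cc1C(=O)N=C(N)N)S(=O)(=O)CC2C` are the two measured members. Among the measured compounds shown here, in a functional assay for inhibition, with Homo sapiens as the target (a higher number here means a weaker inhibitor, a lower number a stronger inhibitor), compound 1 gives 115 nM and compound 2 gives 182 nM so compound 2 stands within the scatter of its only neighbour. Compound 3 `COC1(C)CS(=O)(=O)c2cc(C(=O)N=C(N)N)c(C)cc21` follows from compound 2 through one change methoxy in place of hydrogen on a saturated ring carbon that places methoxy in place of hydrogen on a saturated ring carbon. For the measured compounds named here, the one measured step that bears on this is a 1.6-fold higher number from compound 1 to compound 2 (0.20 log units; within the scatter) for hydrogen in place of hydroxy on a saturated ring carbon. Going by the values given here, no methoxy compound has been measured, so that small step is the only guide, and no change beyond the scatter is expected in this assay. The estimated 1.2-fold lower number from compound 2 to compound 3 (0.08 log units; within the scatter) is a step expected to stay within the scatter. Compound 3 is therefore expected near 150 nM with an estimated range from 60 nM to 380 nM for its value.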

Compound 3, half-maximal inhibitory concentration: 321 nM
For compound 3 the middle estimate is 2.1-fold (0.33 log units) below the measured one, within the range that was stated.
By their numbers in this assay, from the lowest: compounds 1, 2 and 3 (each within the scatter of the next, the first and the last beyond it).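

In this assay placing methoxy on this saturated ring carbon, two ring bonds from the ring sulfur, gives a 1.8-fold higher number from compound 2 to compound 3 (0.25 log units; within the scatter) and so cannot be told apart from hydrogen there. Putting methyl on the oxygen of the hydroxy group gives a 2.8-fold higher number from compound 1 to compound 3 (0.45 log units; beyond the scatter) and is the only step shown at this position that passes the scatter, though it is modest, so hydroxy and methoxy can be told apart while neither can be told from hydrogen. Nothing measured here explains this difference. The compounds shown leave open what a longer ether chain such as ethoxy, or an amine, would give on the same carbon in this assay and whether it would fall nearer hydroxy or methoxy. From the compounds shown here alone, all three compounds also keep the methyl group on that carbon, so its part in these values remains open.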